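The source may hold more compounds than are shown below. What is called first, only, known or untested is meant among the compounds shown, and "the series" means these compounds.

Measured in a functional assay on MV4-11 cells (Homo sapiens) for inhibition, read by resazurin assay, with a stated time of 72 h; on this read-out higher numbers stand for weaker inhibition of growth and lower numbers for stronger inhibition of growth:
compound 1, `COc1ccc(Nc2nccc(-c3cn(C)c4ccccc34)n2)c(OC)c1`: 3410 nM
compound 2, `Oc1ccccc1Nc1nccc(-c2c[nH]c3ccccc23)n1`: 570 nM
compound 3, `COCCOc1nc(C)c(-c2ccnc(Nc3ccc(OC)cc3OC)n2)s1`: 1980 nM

Compound 3 holds the second highest of the three numbers. Its nearest neighbour is compound 1, separated by a gap within the usual scatter, so the two cannot be ordered; compound 2 lies beyond the scatter at a lower number. Compound 4, `COc1ccc(Nc2nccc(-c3sc(SCCCN(C)C)nc3C)n2)c(OC)c1`, differs from compound 3 in one place: (3-(dimethylamino)propyl)sulfanyl in place of 2-methoxyethoxy on an aromatic carbon. Going by the values given here, no measured pair shows this change, so its effect in this assay has no precedent; only a modest step is expected, leaning toward a lower number, as a 1.7-fold lower number from compound 3 to compound 4 (0.22 log units; within the scatter). For compound 4 the estimate is 1200 nM, with an expected range from 400 nM to 3500 nM.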

Compound 4, concentration for 50% growth inhibition: 370 nM
For compound 4 the middle estimate is 3.2-fold (0.51 log units) above the measured one; measured number below the stated range.
By their numbers in this assay, from the lowest: compounds 4 and 2 (each within the scatter of the next); then compounds 3 and 1 (each within the scatter of the next).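

In this assay, the aromatic carbon next to the ring nitrogen and the ring sulfur responds to its substituent: (3-(dimethylamino)propyl)sulfanyl in place of 2-methoxyethoxy gives a 5.4-fold lower number from compound 3 to compound 4 (0.73 log units; beyond the scatter) on the shared core. Going by these compounds alone, this is the first one-place step, and it lies beyond the scatter. Nothing available explains the step.

The change alters the linking atom and the chain end together, leaving open which of them accounts for the step. A 3-(dimethylamino)propoxy chain or a 3-methoxypropylsulfanyl chain at this position would separate the two.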